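The source may hold more compounds than are shown below. What is called first, only, known or untested is meant among the compounds shown, and "the series" means these compounds.

Going by the values given here, in a functional assay on MCF7 cells (Homo sapiens) for inhibition, read by MTT assay, with a stated time of 4 days (on this read-out higher numbers stand for weaker inhibition and lower numbers for stronger inhibition), compound 1 `COc1cc(NC(C)CCCNC(=O)NNC(=O)NCCCCCO)c2ncccc2c1` gives 4000 nM, the only actual number available so far. Compound 2 `CCOC(=O)NC(c1ccccc1)c1ccc(Cl)cc1` is reported only as a limit, > 100000 nM. Among the compounds with values here, compound 1 therefore has no second number to be ranked against, and no step between closely related compounds has been measured. Compound 3 `COc1cc(NC(C)CCCNC(=O)NNC(=O)N(CCO)CCO)c2ncccc2c1` has yet to be tested. It keeps the core of compound 1 but carries bis(2-hydroxyethyl)amino in place of (5-hydroxypentyl)amino on a carbonyl carbon. With only compound 1 at 4000 nM and the structural change itself as a guide, a modest weakening of inhibition is expected in this assay. The expected size of this change is a 2.5-fold higher number from compound 1 to compound 3 (0.40 log units; beyond the scatter). In this assay, the estimate for compound 3 is 10000 nM, with the measurement expected to fall between 3000 nM and 40000 nM.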

Compound 3, half-maximal inhibitory concentration: 29000 nM
Beside the measured number, compound 3's estimate is 2.9-fold (0.46 log units) below it; the measured number falls inside the stated range.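

Going by these compounds alone, compound 3 supplies the first step between closely related compounds in this assay: a 7.3-fold higher number from compound 1 to compound 3 (0.86 log units; beyond the scatter). The carbonyl carbon is thus sensitive to what it carries, since bis(2-hydroxyethyl)amino and (5-hydroxypentyl)amino have the same count of heavy atoms and still give clearly different numbers. Only compound 2 is reported as a limit of the assay, so the change leaves compound 3 with an actual number, unlike that compound: the limit of > 100000 nM in this assay, at which 1 of the 3 values shown sits.

This single step cannot tell whether branching at the nitrogen or the shorter hydroxyethyl chains account for the weaker inhibition, and it gives no cause for the change. A morpholine or a plain hexylamine on the same carbonyl carbon would bear on that question.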